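Pyrazole in place of pyrazine: expected activity of compound 3

This account rests on a few compounds, and the source may have more. Where it says the series, first, only, none or still open, it means among the compounds named here.

Compound 1 `Cc1cccc(-c2ccccc2OCC2=NCCN2)n1` returns only a limit in a functional assay for activation of Alpha-1B adrenergic receptor (Homo sapiens), read by calcium flux (a lower number here means that less compound is needed, a higher number that more compound is needed for the effect), namely < 100000 nM; this is a limit of the assay, not a number. For the measured compounds named here, compound 2 `c1ccc(-c2cnccn2)c(OCC2=NCCN2)c1` is the one compound of the pair with a number: in this assay compound 2 gives 631 nM. Going by the values given here, the only further value shown is the limit (the limit of < 100000 nM in this assay, at which 1 of the 2 values shown sits), so compound 2 cannot be set in order against compound 1 beyond the fact that its own value is a number.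

Compound 3 `c1ccc(-c2cc[nH]n2)c(OCC2=NCCN2)c1` has not yet been measured. It differs from compound 2 in a single place: 1H-pyrazol-3-yl in place of pyrazin-2-yl on an aromatic carbon. Among the compounds with values here, no measured pair carries this change, so there is no step to lean on. The expectation is a modest step in this assay toward a higher number, possibly no further than the usual scatter, written as a 1.9-fold higher number from compound 2 to compound 3 (0.28 log units; within the scatter). Compound 3 is therefore estimated at 1200 nM, with a range from 300 nM to 5000 nM.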

Compound 3, half-maximal effective concentration: 79.4 nM
For compound 3 the middle estimate is 15-fold (1.18 log units) above the measured one; measured number below the stated range.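

In this assay, for the compounds shown here, 1H-pyrazol-3-yl in place of pyrazin-2-yl on an aromatic carbon gives a 7.9-fold lower number from compound 2 to compound 3 (0.90 log units; beyond the scatter) and is the only readable step, so the number at this position does respond to the group it carries. The change replaces a six-membered aromatic ring with a five-membered one and adds a hydrogen-bond donor, but a single step cannot separate these two differences. Nothing measured in the series bears on why the number falls.

Compound 1 gives < 100000 nM as a limit of the assay and not a number, so steps to it cannot be read. From the compounds shown here alone, it remains open whether the hydrogen on the ring nitrogen matters, and how an amine or a carboxylic acid on the same aromatic carbon would read.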